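Replacing Phenoxy with 3-Chlorophenyl in a Benzamide

This account rests on a few compounds, and the source may have more. Where it says the series, first, only, none or still open, it means among the compounds named here.

Compound 2, `Cc1cccc(NC(=O)c2ccc(Oc3ccccc3)cc2)n1`, is the weaker of the two compounds that return a number in an in vitro assay on HEK-293T cells for displacement of a labelled ligand from metabotropic glutamate receptor 5 (Homo sapiens), read by scintillation counting; on this read-out lower numbers stand for stronger inhibition and higher numbers for weaker inhibition: compound 2 gives 7290 nM, whereas compound 1, `Cc1nc(C#Cc2cc(F)cc(C#N)c2)cs1`, gives 0.9 nM, a gap far beyond the scatter. Compound 3, `Cc1cccc(NC(=O)c2ccc(OC(=O)c3ccccc3)cc2)n1`, returns only a limit in this assay, > 10000 nM. Among the compounds with values here, the single step that can be compared, an at least 1.3-fold higher number from compound 2 to compound 3 (0.13 log units; that floor lies within the scatter), rests on that limit, (the limit of > 10000 nM in this assay, at which 1 of the 3 values shown sits), and so carries little information about direction.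

Compound 4, `Cc1cccc(NC(=O)c2ccc(-c3cccc(Cl)c3)cc2)n1`, differs from compound 2 in that (3-chlorophenyl in place of phenoxy on an aromatic carbon). Within the data shown here, no measured compound here carries a 3-chlorophenyl in that place, and the only measured step, which exchanged phenyl for benzoyl on the oxygen, leaves the ring attached through carbon untested. The expectation therefore rests mainly on compound 2 itself, with wide uncertainty: a step of a 2.4-fold lower number from compound 2 to compound 4 (0.39 log units; beyond the scatter) is expected, leaning toward a lower number because compound 2 already sits at 7290 nM and a move away from the weak phenoxy arrangement seems as likely to help as to hurt. Compound 4 is estimated at 3000 nM in this assay, within a range from 400 nM to 20000 nM.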

Compound 4, inhibition constant: 3330 nM
Compound 4: the middle estimate sits 1.1-fold (0.05 log units) below what was measured; measured number inside the range.
By their numbers in this assay, from the lowest: compound 1; then compound 4; then compound 2. At a limit, above all of these: compound 3.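

In this assay, within the data shown here, putting 3-chlorophenyl in place of phenoxy on an aromatic carbon para to a large group gives a 2.2-fold lower number from compound 2 to compound 4 (0.34 log units; beyond the scatter), a modest change but the first at this position that can be read in a direction, whereas the only earlier step rested on a limit. The result shows that the oxygen link is not needed for the compound to return a number in this series, as compound 4 holds its ring directly on the aromatic carbon and still gives a value below that of compound 2. Nothing shown here accounts for the size or direction of this step.

The step removes the oxygen and brings in the chlorine in a single change, and the compounds shown leave open how much of it belongs to each of the two. They also leave open whether a methoxy group or an amine in place of the chlorine would move the number further, and whether any change at this position could bring the shared core much lower than compound 4 stands.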